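Removing One Methoxy Group: Expected Effect on Cell Toxicity

A few compounds are considered here, and "the series" means these few. Any claim that something is new, unique, unknown or untested is made for them only; others in the source may bear on it.

Compound 2 `COc1cc(-c2cc(/C=C/C(=O)c3ccc(N)cc3)[nH]n2)cc(OC)c1OC` and compound 1 `COc1ccc(-c2cc(/C=C/C(=O)c3ccc(N)cc3)[nH]n2)cc1` share one core and differ only in the methoxy groups on one aromatic ring. Both were tested in a functional assay on MOLT-4 cells (Homo sapiens) for inhibition, read by sulforhodamine B assay, with a stated time of 48 h; on this read-out higher numbers stand for lower toxicity in this test and lower numbers for higher toxicity in this test. Compound 2 reaches only the limit of this assay, > 100000 nM, so no number was obtained for it. Compound 1 likewise sits at the limit, > 100000 nM. Compound 2 therefore stands exactly where every value here stands: the limit of > 100000 nM in this assay, at which 2 of the 2 values shown sit.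

Compound 3 `COc1ccc(-c2cc(/C=C/C(=O)c3ccc(N)cc3)[nH]n2)cc1OC` has not yet been measured. It differs from compound 2 by hydrogen in place of methoxy on an aromatic carbon. Going by the values given here, no step between measured compounds exists to judge this change, and with both neighbours at the limit (the limit of > 100000 nM in this assay, at which 2 of the 2 values shown sit), no shift beyond the usual scatter is expected. The expected step is a step that the limit leaves unreadable from compound 2 to compound 3. Compound 3 is thus estimated at 150000 nM, within 50000 nM to 500000 nM, and most likely will again be reported only as a limit.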

Compound 3, concentration lethal to 50% of the cells: > 100000 nM
Compound 3 gave a limit, no number; the forecaster's own chance of this, stated with the estimate: 85%; the middle value is on the limit's open side.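

No step can be read among compound 1, compound 2 and compound 3 in this assay, because each gives only a limit and no number: the limit of > 100000 nM in this assay, at which 3 of the 3 values shown sit.

The compounds shown leave open whether adding or removing a methoxy group on this ring changes the toxicity at all.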